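From 3-Bromophenyl to 3,5-Dimethylphenyl on the Sulfonamide

A few compounds are considered here, and "the series" means these few. Any claim that something is new, unique, unknown or untested is made for them only; others in the source may bear on it.

In a functional assay on M21 cells (Homo sapiens) for antiproliferative activity, read by sulforhodamine B assay, with a stated time of 48 h (on this read-out higher numbers stand for weaker inhibition and lower numbers for stronger inhibition), compound 1 (`CCc1ccccc1NS(=O)(=O)c1ccc(N2CCNC2=O)cc1`) gives 180 nM, compound 2 (`Cc1cccc(NS(=O)(=O)c2ccc(N3CCNC3=O)cc2)c1`) gives 69 nM and compound 3 (`O=C1NCCN1c1ccc(S(=O)(=O)Nc2cccc(Br)c2)cc1`) gives 59 nM. Compound 3 shares the low end of these numbers with compound 2. The data show a 3.1-fold lower number from compound 1 to compound 3 (0.48 log units; beyond the scatter) and a 2.6-fold lower number from compound 1 to compound 2 (0.42 log units; beyond the scatter).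

Compound 4 (`Cc1cc(C)cc(NS(=O)(=O)c2ccc(N3CCNC3=O)cc2)c1`) brings one change: 3,5-dimethylphenyl in place of 3-bromophenyl on a sulfonamide nitrogen. The closest guide is the swap of methyl for bromo, which gave a 1.2-fold lower number from compound 2 to compound 3 (0.07 log units; within the scatter). Within the data shown here, no measured compound carries the 3,5-dimethylphenyl group, so the guide is only partial. The expected change in this assay is a 1.1-fold higher number from compound 3 to compound 4 (0.04 log units; within the scatter), so no shift beyond the scatter is expected. For compound 4 the estimate is 65 nM, with an expected range of 28 nM to 150 nM.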

Compound 4, half-maximal inhibitory concentration: 63 nM
Compound 4: the middle estimate sits 1.0-fold (0.01 log units) above what was measured; measured number inside the range.
By their numbers in this assay, from the lowest: compounds 3, 4 and 2 (each within the scatter of the next); then compound 1.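

Putting 3,5-dimethylphenyl in place of 3-bromophenyl on the sulfonamide nitrogen gives a 1.1-fold higher number from compound 3 to compound 4 (0.03 log units; within the scatter), and methyl in place of hydrogen on an aromatic carbon gives a 1.1-fold lower number from compound 2 to compound 4 (0.04 log units; within the scatter), so neither change moves the number beyond the scatter. The 3,5-dimethylphenyl group also keeps the advantage over 2-ethylphenyl, with a 2.9-fold lower number from compound 1 to compound 4 (0.46 log units; beyond the scatter) as the step beyond the scatter. No available evidence explains these results.

On these data alone, whether a methoxy group, an amine or a carboxylic acid on this phenyl ring would hold the number as low remains open.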